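Changing the Arylmethyl Group on a Shared Amine

The source may hold more compounds than are shown below. What is called first, only, known or untested is meant among the compounds shown, and "the series" means these compounds.

Compound 1 `Oc1ccc(CN[C@@H]2CO[C@H](C(c3ccc(F)cc3)c3ccc(F)cc3)C[C@H]2O)cc1F` gives 7.37 nM in an assay on Cerebral cortex for inhibition of Norepinephrine transporter (Rattus norvegicus); on this read-out higher numbers stand for weaker inhibition and lower numbers for stronger inhibition.
Compound 2 `O[C@@H]1C[C@@H](C(c2ccc(F)cc2)c2ccc(F)cc2)OC[C@H]1NCc1ccc2c(c1)CCO2` gives 25.8 nM in this assay.
Compound 3 `c1ccc(C(c2ccccc2)[C@@H]2CC[C@H](NCc3ccc4occc4c3)CO2)cc1` gives 25.2 nM in this assay.

Among the three measured compounds, compound 2 shows the highest number in this assay; compound 3 sits within the scatter of it, and compound 1 lies clearly lower. Compound 4 `COc1ccc(CN[C@@H]2CO[C@H](C(c3ccc(F)cc3)c3ccc(F)cc3)C[C@H]2O)cn1` differs from compound 2 in one place: a group of 8 heavy atoms (6 carbon, 1 nitrogen, 1 oxygen; one six-membered aromatic ring with 1 hetero atom) in place of a group of 9 heavy atoms (8 carbon, 1 oxygen; one five-membered non-aromatic ring with 1 hetero atom, one six-membered aromatic ring of carbon only), on a saturated chain carbon bound to an amine nitrogen. Going by the values given here, the only measured step that touches the same position is the one from compound 1 to compound 2, where a different aromatic group on that same carbon gave a 3.5-fold higher number from compound 1 to compound 2 (0.54 log units; beyond the scatter). That step shows the arylmethyl group can shift the number by a modest amount, but it gives no direct reading on the 6-methoxypyridin-3-yl group itself, and compound 3 carries a different core, so its value cannot be compared as a single step. Compound 4 is therefore expected to stay near compound 2, with a change of a 1.3-fold lower number from compound 2 to compound 4 (0.11 log units; within the scatter) in this assay that could fall on either side of the scatter. The estimate for compound 4 in this assay is 20 nM, with a range from 6 nM to 70 nM.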

Compound 4, inhibition constant: 28.4 nM
For compound 4 the middle estimate is 1.4-fold (0.15 log units) below the measured one; low and high end bracket the measured number.
By their numbers in this assay, from the lowest: compound 1; then compounds 3, 2 and 4 (each within the scatter of the next).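

At the saturated chain carbon bound to an amine nitrogen, bringing in 6-methoxypyridin-3-yl gives a 1.1-fold higher number from compound 2 to compound 4 (0.04 log units; within the scatter) in this assay, so this assay does not tell that group apart from the bicyclic group it replaces, even though the two differ in ring type and in hydrogen-bond acceptors. Going by these compounds alone, measured against the 3-fluoro-4-hydroxyphenyl group, the same new group gives a 3.9-fold higher number from compound 1 to compound 4 (0.59 log units; beyond the scatter), and with the earlier step, a 3.5-fold higher number from compound 1 to compound 2 (0.54 log units; beyond the scatter), this leaves compound 1 as the only one of the compounds on the shared core that stands apart, with two different arylmethyl groups now both giving clearly higher numbers than it does. No measurement in hand accounts for either step, or for what sets the 3-fluoro-4-hydroxyphenyl group apart.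

The compounds shown leave open whether the lower number of compound 1 goes with the hydroxyl, with the fluorine or with the two together, which a 4-hydroxyphenyl or a 3-fluorophenyl group on the same carbon would separate. They also leave open whether a 6-hydroxypyridin-3-yl group at this position would read like compound 1 or like compound 4.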